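From 3-methylphenyl to 4-hydroxyphenyl: what to expect

The compounds below may be only part of what the source reports. "The series", "measured", "known", "first", "only" and "open" are said of these compounds alone.

Compound 1 `O=C(/C=C/c1ccc2c(c1)B(O)OC2)c1ccc(C(F)(F)F)cc1` gives > 10 ug/mL (a limit)
Compound 2 `O=C(/C=C/c1ccc2c(c1)B(O)OC2)c1ccco1` gives > 10 ug/mL (a limit)
Compound 3 `Cc1cccc(C(=O)/C=C/c2ccc3c(c2)B(O)OC3)c1` gives 8.56 ug/mL

All three values come from an ADME assay on L929 cells (Mus musculus) for cytotoxicity, read by resazurin assay, with a stated time of 72 h; on this read-out higher numbers stand for weaker inhibition and lower numbers for stronger inhibition. Within the data shown here, compound 3 holds the only true number so far, 8.56 ug/mL. Compound 1 and compound 2 both rest at the limit of > 10 ug/mL in this assay, at which 2 of the 3 values shown sit.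

Compound 4 `O=C(/C=C/c1ccc2c(c1)B(O)OC2)c1ccc(O)cc1` carries 4-hydroxyphenyl in place of 3-methylphenyl on a carbonyl carbon. Among the measured compounds shown here, one measured step bears on this position, a different swap at the same carbonyl carbon: an at least 1.1-fold lower number from compound 2 to compound 3 (0.06 log units; that floor lies within the scatter). On that slim basis, a 1.1-fold higher number from compound 3 to compound 4 (0.02 log units; within the scatter) is expected to stay within the scatter, with no clear direction. Compound 4 is estimated at 9 ug/mL, with an expected range from 4 ug/mL to 20 ug/mL.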

Compound 4, half-maximal inhibitory concentration: > 10 ug/mL
Compound 4: no number, only a limit (the forecaster's own chance of this, stated with the estimate: 40%); middle value at least 1.1-fold (0.04 log units) from the limit.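

Like compound 1 and compound 2, compound 4 gives a limit and no number: the limit of > 10 ug/mL in this assay, at which 3 of the 4 values shown sit. Putting 4-hydroxyphenyl in place of 3-methylphenyl on the carbonyl carbon gives an at least 1.1-fold higher number from compound 3 to compound 4 (0.06 log units; that floor lies within the scatter), so no clear change is shown, though the limit hides the true size of the step. The steps from compound 1 and from compound 2 to compound 4 cannot be read, since both ends are limits.

As far as these compounds go, how far the true values of compound 1, compound 2 and compound 4 lie beyond the limit stays open. So does whether an amine or a carboxylic acid in place of the hydroxy would give a clearly lower number.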